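A few compounds are considered here, and "the series" means these few. Any claim that something is new, unique, unknown or untested is made for them only; others in the source may bear on it.

Compound 1 `CN1CCN(CCCOc2cccc3nc(Nc4ccc(Cl)c(C(F)(F)F)c4)ccc23)CC1`: 1630 nM
Compound 2 `CC(C)c1ccc(Nc2ccc3c(OCCCN4CCN(C)CC4)cccc3n2)cc1`: 7280 nM
Compound 3 `CN1CCN(CCCOc2cccc3nc(Nc4ccc(F)c(F)c4)ccc23)CC1`: 2110 nM

These three compounds share one core and differ only in the aromatic group carried on a nitrogen on an aromatic ring. In a functional assay on RXF 393 cells (Homo sapiens) for inhibition, read by sulforhodamine B assay, with a stated time of 48 h (on this read-out lower numbers stand for stronger inhibition of growth and higher numbers for weaker inhibition of growth), compound 3 gives 2110 nM, the second highest of the three numbers. Its nearest neighbour is compound 1, and the gap is a 1.3-fold higher number from compound 1 to compound 3 (0.11 log units; within the scatter). The furthest is compound 2, from which the gap is a 3.5-fold lower number from compound 2 to compound 3 (0.54 log units; beyond the scatter).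

Compound 4 `CN1CCN(CCCOc2cccc3nc(Nc4cccc(Cl)c4)ccc23)CC1` has not yet been measured in this assay. It differs from compound 3 in one place: 3-chlorophenyl in place of 3,4-difluorophenyl on a nitrogen on an aromatic ring. Within the data shown here, two measured steps bear on this change. One swaps one halogen-bearing phenyl for another, and there a 1.3-fold higher number from compound 1 to compound 3 (0.11 log units; within the scatter). The other swaps a phenyl without halogens for one with halogens, and there a 3.5-fold lower number from compound 2 to compound 3 (0.54 log units; beyond the scatter). Compound 4 again carries a halogen on the phenyl, and because a 1.3-fold higher number from compound 1 to compound 3 (0.11 log units; within the scatter) stayed within the scatter while a 3.5-fold lower number from compound 2 to compound 3 (0.54 log units; beyond the scatter) did not, the step from compound 3 to compound 4 is expected to be small: a 1.2-fold higher number from compound 3 to compound 4 (0.07 log units; within the scatter). Compound 4 is therefore estimated at 2500 nM, with a range from 1000 nM to 6500 nM.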

Compound 4, concentration for 50% growth inhibition: 1850 nM
The estimate for compound 4 lay 1.4-fold (0.13 log units) above the measured number, and the stated range covers the measured number.
By their numbers in this assay, from the lowest: compounds 1, 4 and 3 (each within the scatter of the next); then compound 2.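

In this assay, the single chlorine of the 3-chlorophenyl group cannot be told apart from the two fluorines of the 3,4-difluorophenyl group (a 1.1-fold lower number from compound 3 to compound 4 (0.06 log units; within the scatter)), nor from the chlorine and trifluoromethyl pair on the phenyl of compound 1 (a 1.1-fold higher number from compound 1 to compound 4 (0.05 log units; within the scatter)). The change away from 4-isopropylphenyl gives the only clear difference (a 3.9-fold lower number from compound 2 to compound 4 (0.59 log units; beyond the scatter)), so all three halogen-bearing phenyl groups on this nitrogen now sit together and compound 2, the weakest of the four, stands apart, with one chlorine on the phenyl proving enough to keep compound 4 in the halogen-bearing group. Nothing available here explains why these three groups give such similar numbers.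

The compounds shown leave open whether a halogen is needed at all or whether a plain phenyl, or a phenyl carrying a methoxy group, would sit with the halogen-bearing compounds just as well. They also leave open whether a phenyl bearing an amine or a carboxylic acid would stay with that group or fall as far from it as compound 2 does.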